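The compounds below may be only part of what the source reports. "The series", "measured", "known", "first", "only" and "open" are said of these compounds alone.

Three compounds built on one shared core were run in a functional assay on SK-OV-3 cells (Homo sapiens) for antiproliferative activity, read by MTT assay, with a stated time of 72 h; on this read-out lower numbers stand for stronger inhibition and higher numbers for weaker inhibition. Compound 1 `CC(C)(C)OC(=O)NCc1ccc(NC(=O)CCc2cccc3c2B(O)OC3)cc1` gives 2000 nM, compound 2 `C#Cc1ccccc1NC(=O)CCc1cccc2c1B(O)OC2` gives 820 nM, and compound 3 `O=C(CCc1cccc2c1B(O)OC2)Nc1cccc(-c2ccc(F)cc2)c1` gives 93 nM. Compound 3 therefore shows the lowest number of the three, and its gaps to compound 2 and to compound 1 both lie beyond the usual scatter of repeated measurements.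

The next compound, compound 4 `N#Cc1ccc(-c2cccc(NC(=O)CCc3cccc4c3B(O)OC4)c2)cc1`, differs from compound 3 by cyano in place of fluoro on an aromatic carbon. Among the measured compounds shown here, no pair of measured compounds shows this same change, so there is nothing to read a direction from; in this assay the change is expected to give a 1.2-fold higher number from compound 3 to compound 4 (0.07 log units; within the scatter), a step no larger than the scatter. On that basis compound 4 is estimated at 110 nM, with a range from 40 nM to 300 nM.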

Compound 4, half-maximal inhibitory concentration: 340 nM
Compound 4: the middle estimate sits 3.1-fold (0.49 log units) below what was measured; measured number above the stated range.
By their numbers in this assay, from the lowest: compound 3; then compound 4; then compound 2; then compound 1.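

Among the compounds shown here, compound 3 and compound 4 form the first pair that differs in one place, and in this assay the change from 4-fluorophenyl to 4-cyanophenyl gives a 3.7-fold higher number from compound 3 to compound 4 (0.56 log units; beyond the scatter) on this reading. The position para to a large group therefore responds to the group it carries, and here cyano gives the weaker inhibition, though the step is modest. Nothing available accounts for this step.

The compounds shown leave open how an amine, a carboxylic acid or a methoxy group would read at this position. They also leave open whether cyano in place of fluoro gives a step of the same direction at any other position.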